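Fluorophenyl swap: from compound 2 to compound 3

The source may report more compounds than this note shows. Statements on the series, on what has been measured and on what is new or still open speak of the compounds shown alone.

Values in a functional assay on the whole organism for inhibition, with Mythimna separata as the target, with a stated time of 5 days; on this read-out higher numbers stand for an effect only at larger amounts of compound and lower numbers for an effect already at smaller amounts:
- compound 1 `Cc1ccc(-c2nnc(COc3cnn(C(C)(C)C)c(=O)c3Cl)o2)cc1`: 19900 nM
- compound 2 `CC(C)(C)n1ncc(OCc2nnc(-c3cc(F)c(F)cc3F)o2)c(Cl)c1=O`: 75700 nM

Compound 2, at 75700 nM, holds the higher of the two numbers. Compound 3 `CC(C)(C)n1ncc(OCc2nnc(-c3ccc(F)cc3)o2)c(Cl)c1=O` is the next entry, with 4-fluorophenyl in place of 2,4,5-trifluorophenyl on an aromatic carbon. Within the data shown here, only one measured step bears on this, the modest 3.8-fold higher number from compound 1 to compound 2 (0.58 log units; beyond the scatter), which introduced the group now leaving. A move of similar or smaller size toward a lower number is therefore expected in this assay. The expected change is a 2.4-fold lower number from compound 2 to compound 3 (0.37 log units; beyond the scatter). For compound 3 the estimated value is 32000 nM, with an expected range of 12000 nM to 80000 nM.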

Compound 3, half-maximal effective concentration: 5200 nM
For compound 3 the middle estimate is 6.2-fold (0.79 log units) above the measured one; the measured number lies below the stated range.
By their numbers in this assay, from the lowest: compound 3; then compound 1; then compound 2.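

In this assay, the aryl group on the five-membered aromatic ring proves far more sensitive than the earlier pair suggested: 4-fluorophenyl in place of 2,4,5-trifluorophenyl gives a 15-fold lower number from compound 2 to compound 3 (1.16 log units; beyond the scatter), reversing the earlier rise and going past compound 1. Fluoro in place of methyl on this aryl group gives a 3.8-fold lower number from compound 1 to compound 3 (0.58 log units; beyond the scatter), so compound 3 has the lowest number of the three, with both steps beyond the scatter. Nothing on hand bears on the reason for these steps.

Open, going by these compounds, is how 4-chlorophenyl, 4-methoxyphenyl or unsubstituted phenyl would compare with 4-fluorophenyl here. A difluorophenyl would help locate the trifluorophenyl penalty.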